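A substituted aryl group on the shared core

The source may hold more compounds than are shown below. What is called first, only, known or untested is meant among the compounds shown, and "the series" means these compounds.

Measured compounds:
compound 1 `O=C(Nc1ccc(Oc2ccnc3[nH]ccc23)cc1)c1cn(-c2ccccc2)c2ccccc2c1=O`, 3560 nM
compound 2 `O=C(Nc1ccc(Oc2ccnc3[nH]ccc23)cc1)c1cn(-c2ccc(Br)cc2)c2ccccc2c1=O`, 610 nM
compound 3 `Cn1ccc2c(Oc3ccc(NC(=O)c4cn(-c5ccccc5)c5ccccc5c4=O)cc3F)ccnc21`, 2790 nM

In a functional assay on MCF7 cells (Homo sapiens) for inhibition, read by MTT assay, with a stated time of 72 h (on this read-out higher numbers stand for weaker inhibition and lower numbers for stronger inhibition), compound 3 gives 2790 nM, the second highest of the three numbers; compound 1 lies within the scatter of it, while compound 2 gives 610 nM, a clearly lower number. Compound 4 `Cn1ccc2c(Oc3ccc(NC(=O)c4cn(-c5ccc(C(F)(F)F)cc5Cl)c5ccccc5c4=O)cc3F)ccnc21` differs from compound 3 in one place: 2-chloro-4-(trifluoromethyl)phenyl in place of phenyl on an aromatic nitrogen. Among the compounds with values here, the only measured step that bears on this is a 5.8-fold lower number from compound 1 to compound 2 (0.77 log units; beyond the scatter), where a halogen on the same aryl ring brought the number down beyond the scatter. Compound 4 carries a larger substituent set on that ring, and nothing measured tells how the chloro at the 2-position adds to the trifluoromethyl. The step is therefore expected to resemble a 5.8-fold lower number from compound 1 to compound 2 (0.77 log units; beyond the scatter) in direction, giving an estimated 4.0-fold lower number from compound 3 to compound 4 (0.60 log units; beyond the scatter) in this assay. Compound 4 is thus expected to give about 700 nM, within 250 nM to 2000 nM.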

Compound 4, half-maximal inhibitory concentration: 190 nM
Compound 4: middle estimate off by 3.7-fold (0.57 log units), on the high side; the measured number lies below the stated range.
By their numbers in this assay, from the lowest: compound 4; then compound 2; then compounds 3 and 1 (each within the scatter of the next).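

In this assay, the replacement of phenyl on the aromatic nitrogen by 2-chloro-4-(trifluoromethyl)phenyl gives a 15-fold lower number from compound 3 to compound 4 (1.17 log units; beyond the scatter). Set beside a 5.8-fold lower number from compound 1 to compound 2 (0.77 log units; beyond the scatter), this shows that the number falls with substitution of this aryl ring on two different versions of the core, not only with a single bromo, and that the position accepts a group of 11 heavy atoms in place of 6 with a large step in the same direction. No measurement at hand accounts for the size of this step.

The compounds shown leave open how the step divides between the chloro and the trifluoromethyl, and whether either alone would lower the number on the core of compound 3. They also leave open how this ring would respond to an amine or a carboxylic acid in place of these halogen-bearing groups.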